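Removing the methyl from a weakly active phenylethynyl pyrimidine

The source may hold more compounds than are shown below. What is called first, only, known or untested is meant among the compounds shown, and "the series" means these compounds.

Measured compounds:
- compound 1, `CC(C)(C)c1ncc(C#Cc2ccccc2)cn1`: 247000 nM in an assay on HEK293 cells for positive allosteric modulation of metabotropic glutamate receptor 5 (Rattus norvegicus); on this read-out higher numbers stand for an effect only at larger amounts of compound and lower numbers for an effect already at smaller amounts
- compound 2, `CCc1ncc(C#Cc2ccccc2)cn1`: "not active" (no number reported)
- compound 3, `CSc1ncc(C#Cc2ccc(C)cc2)cn1`: "not active" (no number reported)

Of the compounds shown here, three sharing the same core have been measured in this assay. Compound 1 gives 247000 nM, a weak effect seen only at very large amounts. Compound 2 is recorded as "not active" (no number reported), with no number. Among the compounds with values here, compound 3 stands in the same place: in this assay compound 3 is reported as "not active" (no number reported), so it has no number of its own and sits with compound 2 among the entries without a value, with no step computed from it to any other compound.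

Compound 4, `CSc1ncc(C#Cc2ccccc2)cn1`, has not yet been measured. It differs from compound 3 by hydrogen in place of methyl on an aromatic carbon. Within the data shown here, no measured pair shows what this change does here, so there is nothing to set a direction from; the only guide is that every compound in this set is weak or without effect, and the core of compound 4 otherwise matches compound 1 and compound 2.

On that basis compound 4 is expected to show at most a weak effect in this assay, with an estimated value near 200000 nM, within a range from 50000 nM to 1000000 nM, and a real chance that only an inactive outcome is reported.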

Compound 4, half-maximal effective concentration: 120000 nM
Estimate against measurement, compound 4: 1.7-fold (0.22 log units) above, within the range that was stated.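

In this assay compound 4 gives 120000 nM, which shows that a compound carrying methylsulfanyl on the shared core can have a measurable effect, although only at large amounts. Methylsulfanyl in place of tert-butyl on an aromatic carbon brings a 2.1-fold lower number from compound 1 to compound 4 (0.31 log units; beyond the scatter), a modest step and the first comparison between two numbers in this set. The steps to compound 2 and compound 3 cannot be read, as neither has a number; for the change from methyl to hydrogen on the aromatic carbon para to a large group, the record shows only that compound 3 is listed as "not active" (no number reported), while compound 4 has a value.

The compounds shown leave open whether an amine, a methoxy group or a longer chain in place of methylsulfanyl, or fluorine or chlorine in place of that hydrogen, would shift the value further in this assay. Nothing available here accounts for the step or for the difference between the compound with a value and the one without.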